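A few compounds are considered here, and "the series" means these few. Any claim that something is new, unique, unknown or untested is made for them only; others in the source may bear on it.

Measured so far:
compound 1, `O=[N+]([O-])c1c(CS(=O)(=O)c2ccccc2)nc2c(-c3ccc(Cl)cc3)cc(Cl)cn12`, > 3900 nM in an ADME assay on HepG2 cells (Homo sapiens) for cytotoxicity, read by MTT assay, with a stated time of 72 h; a lower number here means that less compound is tolerated, a higher number that more compound is tolerated
compound 2, `CCN(CC)c1ccc(-c2cc(Cl)cn3c([N+](=O)[O-])c(CS(=O)(=O)c4ccccc4)nc23)cc1`, > 15600 nM in this assay
compound 3, `O=[N+]([O-])c1c(CS(=O)(=O)c2ccccc2)nc2c(-c3ccc(CO)cc3)cc(Cl)cn12`, 13100 nM in this assay

The values of compound 1 and compound 2 are limits of this assay, not numbers. Compound 3 therefore stands alone with the only number shown; the two further values are limits. The step that the limit leaves unreadable from compound 1 to compound 3 cannot be read because of the limit of > 3900 nM in this assay, at which 1 of the 3 values shown sits. Among the measured compounds shown here, the step of an at least 1.1-fold lower number from compound 2 to compound 3 (0.07 log units; that floor lies within the scatter) is the one readable comparison, and its floor lies within the scatter.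

Compound 4, `O=[N+]([O-])c1c(CS(=O)(=O)c2ccccc2)nc2c(-c3ccccc3F)cc(Cl)cn12`, has not yet been measured in this assay. It differs from compound 3 in one place: 2-fluorophenyl in place of 4-(hydroxymethyl)phenyl on an aromatic carbon. For the measured compounds named here, the only measured step that bears on a change at this position is an at least 1.1-fold lower number from compound 2 to compound 3 (0.07 log units; that floor lies within the scatter), and it gives no sign of a move beyond the scatter; the step from compound 1 to compound 3 is left unreadable by the limit of > 3900 nM in this assay, at which 1 of the 3 values shown sits. Compound 4 is therefore expected to sit near compound 3, with a 1.3-fold lower number from compound 3 to compound 4 (0.12 log units; within the scatter) as an expected step of no clear direction beyond the scatter. The estimate for compound 4 in this assay is 10000 nM, with a range from 4000 nM to 25000 nM.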

Compound 4, half-maximal cytotoxic concentration: > 3900 nM
Compound 4 gave a limit, no number; the forecaster's own chance of this, stated with the estimate: 40%; the middle value does not contradict the limit.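

In this assay compound 4 gives > 3900 nM, which is a limit and not a number. Among the compounds shown here, no step to compound 4 from compound 1, compound 2 or compound 3 can be read. The compounds shown leave open how far the group on this aromatic carbon shifts the value in this assay, with compound 3 still the only one carrying a number.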